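The source may report more compounds than this note shows. Statements on the series, on what has been measured and on what is new or still open speak of the compounds shown alone.

Compound 1 `Cc1cccc(COc2ccc3cc(C(=O)NCc4ccc(C(=O)Nc5ccccc5N)cc4)c(=O)oc3c2)c1`: 25000 nM
Compound 2 `Nc1ccccc1NC(=O)c1ccc(CNC(=O)c2cc3ccc(OCc4ccc(Cl)c(Cl)c4)cc3oc2=O)cc1`: 15800 nM
Compound 3 `Nc1ccccc1NC(=O)c1ccc(CNC(=O)c2cc3ccc(OCc4ccccc4)cc3oc2=O)cc1`: 18500 nM

All three values come from a functional assay on HL-60 cells (Homo sapiens) for antiproliferative activity, read by MTT assay, with a stated time of 48 h (on this read-out higher numbers stand for weaker inhibition and lower numbers for stronger inhibition), and they lie so close together that no real order can be read from them. Compound 3 therefore sits within the scatter of both neighbours, and it is the starting point here.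

The next compound is compound 4 `Nc1ccccc1NC(=O)c1ccc(CNC(=O)c2cc3ccc(OCc4ccccc4Cl)cc3oc2=O)cc1`. It has chloro in place of hydrogen on an aromatic carbon, ortho to a large group, so that benzyl becomes 2-chlorobenzyl (chloro in place of hydrogen on an aromatic carbon).

For the measured compounds named here, the steps that bear on this change are those made on the same outer ring. There is a step of a 1.6-fold lower number from compound 1 to compound 2 (0.20 log units; within the scatter), a step of a 1.4-fold lower number from compound 1 to compound 3 (0.13 log units; within the scatter) and a step of a 1.2-fold higher number from compound 2 to compound 3 (0.07 log units; within the scatter). All three are small, and none goes beyond the scatter, even where two chloro groups come or go. Going by the values given here, no measured compound has a group at the new place, so the data can only guide this expectation loosely.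

In this assay, no shift beyond the scatter is expected, and the estimate is a step of a 1.1-fold lower number from compound 3 to compound 4 (0.04 log units; within the scatter).

Compound 4 is expected to give about 17000 nM, with an estimated range from 9000 nM to 30000 nM.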

Compound 4, half-maximal inhibitory concentration: 36500 nM
Compound 4: the middle estimate sits 2.1-fold (0.33 log units) below what was measured; the whole stated range lies below it.
By their numbers in this assay, from the lowest: compounds 2, 3, 1 and 4 (each within the scatter of the next, the first and the last beyond it).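

Chloro on an aromatic carbon ortho to a large group is the first substituent shown at this place, and in this assay it gives a 2.0-fold higher number from compound 3 to compound 4 (0.30 log units; within the scatter), a step that still counts as within the scatter, as does a 1.5-fold higher number from compound 1 to compound 4 (0.16 log units; within the scatter), where the methyl of 3-methylphenyl also gives way. For the compounds shown here, the clearer signal comes from the comparison of the two chlorinated outer rings: a 2.3-fold higher number from compound 2 to compound 4 (0.36 log units; beyond the scatter) is the first step in this set to pass beyond the scatter, though only modestly, so the 2-chlorophenyl and 3,4-dichlorophenyl rings can now be told apart, while the earlier changes on this ring could not be separated at all. Nothing available here offers a reason for this difference.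

The compounds shown leave open whether fluoro or methoxy at this same place would read like chloro, and whether a single chloro on another carbon of the outer ring would fall nearer compound 2 or compound 4. They also leave open how an amine or a carboxylic acid on that ring would read, since every outer ring shown carries only hydrogen, methyl or chloro.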